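The source may hold more compounds than are shown below. What is called first, only, known or untested is meant among the compounds shown, and "the series" means these compounds.

compound 1 `Cc1cccc(NC(=O)Nc2cccc(Cl)c2)c1C`: "not active" (no number reported)
compound 2 `Cc1cc(C)cc(NC(=O)Nc2cccc(Cl)c2)c1`: 906000 nM

In a physicochemical assay for inhibition, with a stated time of 7 days (a higher number here means a weaker inhibitor, a lower number a stronger inhibitor), compound 1 is reported as "not active" (no number reported), so it has no single number to stand on. Going by the values given here, the only number so far is for compound 2, which gives 906000 nM, a very high concentration that marks a weak inhibitor. The next compound to be measured is compound 3 `Cc1cccc(NC(=O)Nc2ccccc2)c1C`. The structural change is hydrogen in place of chloro on an aromatic carbon. Among the compounds with values here, no measured pair shows what this swap does here, so the size of the step cannot be read from the data. A large move toward stronger inhibition is not expected, given that compound 1 reads "not active" (no number reported) and compound 2 reads 906000 nM. If a number is reported at all, compound 3 is expected at about 1000000 nM, within an estimated range of 300000 nM to 3000000 nM.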

Compound 3, half-maximal inhibitory concentration: "not active" (no number reported)
For compound 3 the study gives words and no number, and the estimate cannot be compared.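

Compound 1 and compound 3 are both reported in words rather than numbers, so no step can be read between them. No measurement shown offers an explanation for this result. The compounds shown leave open how much replacing chloro with hydrogen changes inhibition.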